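The source may hold more compounds than are shown below. What is called first, only, known or untested is meant among the compounds shown, and "the series" means these compounds.

Compound 1 `Cc1n[nH]c(C(=O)O)c1Cc1cccc(C(F)(F)F)c1` gives 300 nM in an assay on isolated protein for inhibition of 2-Hydroxyacid oxidase 2 (Rattus norvegicus) (a higher number here means a weaker inhibitor, a lower number a stronger inhibitor), the lowest of the two numbers in hand. Compound 2 `Cc1n[nH]c(C(=O)O)c1Cc1ccc(-c2ccc(C(F)(F)F)cc2)cc1` gives 1100 nM in this assay, a gap beyond the scatter. Compound 3 `Cc1n[nH]c(C(=O)O)c1Cc1cccc(C(N)=O)c1` is not yet measured; it differs from compound 1 by carbamoyl in place of trifluoromethyl on an aromatic carbon. Going by the values given here, no measured pair in the set carries this change, so its size has no anchor here. A step of a 3.0-fold higher number from compound 1 to compound 3 (0.48 log units; beyond the scatter) is expected, a loss beyond the scatter, though the direction is uncertain. For compound 3 in this assay the estimate is 900 nM, expected between 250 nM and 3500 nM.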

Compound 3, half-maximal inhibitory concentration: 900 nM
The estimate for compound 3 equals the measured number at the digits printed, within the range that was stated.
By their numbers in this assay, from the lowest: compound 1; then compounds 3 and 2 (each within the scatter of the next).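

In this assay, this place on the ring, meta to a large group, now has its first single-change comparison: carbamoyl in place of trifluoromethyl gives a 3.0-fold higher number from compound 1 to compound 3 (0.48 log units; beyond the scatter), a modest loss beyond the scatter. So this change does not improve on trifluoromethyl here, although compound 3 still gives a measurable value. No data at hand bear on the reason for this step.

Still open, from the compounds shown here alone, is how a nitrile, an amine or a carboxylic acid at this place would compare with carbamoyl. Going by these compounds, the effect of substituting the carbamoyl nitrogen with a methyl also remains open.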